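A few compounds are considered here, and "the series" means these few. Any claim that something is new, unique, unknown or untested is made for them only; others in the source may bear on it.

Compound 2, `CCCOC(=O)C1=C(C)N(C)C(=O)NC1c1cccs1`, is the starting point of this account. Among the compounds with values here, in an assay on membranes from HeLa cells for displacement of a labelled ligand from adenosine receptor A3 (Homo sapiens), read by scintillation counting, with a stated time of 180 min, tested at 1 uM (on this read-out lower numbers stand for less inhibition and higher numbers for more inhibition at the one concentration tested (going by the name of the read-out)), compound 2 gives 4%, the lowest of the two numbers so far, though compound 1, `CC1=C(C(=O)OC(C)(C)C)C(c2ccoc2)NC(=O)N1C`, with 12% in this assay, lies within the scatter of it. Within the data shown here, the single change to compound 3, `CC1=C(C(=O)OC(C)(C)C)C(c2cccs2)NC(=O)N1C`, is tert-butyl in place of propyl on an oxygen next to a carbonyl group. Among the measured compounds shown here, no measured pair shows this exchange, so the expected step is estimated at a number 4 percentage points higher from compound 2 to compound 3 (within the scatter), not beyond the scatter in either direction. Compound 3 is therefore expected to give about 8% in this assay, within a range from 0% to 22%.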

Compound 3, a percentage reported as inhibition, at one concentration (the size of the read-out at that concentration, not a potency): 22%
Compound 3: middle estimate off by 14 percentage points, on the low side; measured number inside the range.
By their numbers in this assay, from the lowest: compounds 2, 1 and 3 (each within the scatter of the next, the first and the last beyond it).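

In this assay, within the data shown here, tert-butyl in place of propyl on an oxygen next to a carbonyl group gives a number 18 percentage points higher from compound 2 to compound 3 (beyond the scatter) and is the first exchange at this position that can be read. Thiophen-2-yl in place of furan-3-yl on a saturated ring carbon, with tert-butyl kept on the oxygen, gives a number 10 percentage points higher from compound 1 to compound 3 (within the scatter) and so cannot be told apart from no change. Nothing available accounts for the rise seen with tert-butyl.

As far as these compounds go, what a longer chain or a benzyl group on this oxygen would give stays open. So does the effect of tert-butyl in place of propyl when furan-3-yl sits on the saturated ring carbon.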